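The source may report more compounds than this note shows. Statements on the series, on what has been measured and on what is new or still open speak of the compounds shown alone.

Measured so far:
compound 1 `O=C(Nc1cccc(C(F)(F)F)c1)Nc1nnc(Sc2ncnc3scc(-c4ccncc4)c23)s1` gives 15300 nM in a functional assay on HepG2 cells (Homo sapiens) for antiproliferative activity, read by MTT assay, with a stated time of 48 h; on this read-out lower numbers stand for stronger inhibition and higher numbers for weaker inhibition
compound 2 `COc1ccc(NC(=O)Nc2nnc(Sc3ncnc4scc(-c5ccncc5)c34)s2)cc1` gives 14600 nM in this assay

Compound 2 stands with the lowest of the two numbers, but its nearest neighbour, compound 1, is within the scatter: the step of a 1.0-fold lower number from compound 1 to compound 2 (0.02 log units; within the scatter) means the two compounds cannot be told apart on these data, although they carry different aromatic groups on the amide-type nitrogen.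

Compound 3 `O=C(Nc1ccc(Cl)c(Cl)c1)Nc1nnc(Sc2ncnc3scc(-c4ccncc4)c23)s1` is not yet measured. It differs from compound 2 in one place: 3,4-dichlorophenyl in place of 4-methoxyphenyl on an amide-type nitrogen.

Within the data shown here, the only measured step, the one from compound 1 to compound 2, is the sole guide. It also swapped the group on that nitrogen and left the number essentially unchanged. A third aromatic group at the same place is therefore expected to behave alike, with no step beyond the scatter in this assay. The estimate for compound 3 is 13000 nM, ranging from 4500 nM to 38000 nM, an expected step of a 1.1-fold lower number from compound 2 to compound 3 (0.05 log units; within the scatter).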

Compound 3, half-maximal inhibitory concentration: 61900 nM
Compound 3: the middle estimate sits 4.8-fold (0.68 log units) below what was measured, and the stated range ends below it.
By their numbers in this assay, from the lowest: compounds 2 and 1 (each within the scatter of the next); then compound 3.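

The aromatic group on the amide-type nitrogen is not as interchangeable as the first two compounds suggested. In this assay, 3,4-dichlorophenyl gives a 4.2-fold higher number from compound 2 to compound 3 (0.63 log units; beyond the scatter) and a 4.0-fold higher number from compound 1 to compound 3 (0.61 log units; beyond the scatter), so this position does respond to what it carries, and here the change weakens inhibition against both earlier groups. Nothing available explains why this group stands apart from 4-methoxyphenyl and 3-(trifluoromethyl)phenyl.

Among these compounds, with only three groups compared, it remains open whether the weakening comes from having two chlorine atoms on the ring or from something else about this particular group. Plain phenyl, a phenyl carrying a single chlorine, and a phenyl carrying an amine or a carboxylic acid would all test this, and any of them might move the number in either direction.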